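Moving one methyl group on a phenyl ring

The compounds below may be only part of what the source reports. "The series", "measured", "known", "first", "only" and "open" are said of these compounds alone.

Compound 1 `CC1(C)[C@H]2CC[C@]1(C)N(Cc1cn(-c3ccccc3Br)nn1)C(=O)C2` gives 280 nM
Compound 2 `Cc1ccccc1-n1cc(CN2C(=O)C[C@@H]3CC[C@@]2(C)C3(C)C)nn1` gives 250 nM

Both numbers come from a functional assay on PANC-1 cells (Homo sapiens) for inhibition, read by MTT assay, with a stated time of 24 h (on this read-out lower numbers stand for stronger inhibition and higher numbers for weaker inhibition), and they sit within the usual scatter of each other, so compound 2 cannot be ranked apart from compound 1 on these data. Among the measured compounds shown here, the one measured step is a 1.1-fold lower number from compound 1 to compound 2 (0.05 log units; within the scatter) and it comes from methyl in place of bromo on an aromatic carbon.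

Compound 3 `Cc1cccc(-n2cc(CN3C(=O)C[C@@H]4CC[C@@]3(C)C4(C)C)nn2)c1` keeps the shared core of compound 2 and changes one group: 3-methylphenyl in place of 2-methylphenyl on an aromatic nitrogen describes it, with 3-methylphenyl in place of 2-methylphenyl on an aromatic nitrogen. The two compounds hold the same atoms, joined differently. For the measured compounds named here, no measured compound carries the methyl in this new place, so the evidence is thin. The measured step changed a substituent on the same phenyl ring and stayed within the scatter, which gives no direction to follow. The expected result is therefore a 1.2-fold higher number from compound 2 to compound 3 (0.08 log units; within the scatter) and no real shift in either direction is anticipated. For compound 3 the estimated value is 300 nM with an expected range from 110 nM to 800 nM in this assay as the test.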

Compound 3, half-maximal inhibitory concentration: 240 nM
Beside the measured number, compound 3's estimate is 1.3-fold (0.10 log units) above it; low and high end bracket the measured number.
By their numbers in this assay, from the lowest: compounds 3, 2 and 1 (each within the scatter of the next).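

The new result adds a kind of change the earlier pair did not hold, a methyl group placed differently on the same phenyl ring with the atom count untouched: in this assay there is a 1.0-fold lower number from compound 2 to compound 3 (0.02 log units; within the scatter) for 3-methylphenyl in place of 2-methylphenyl on an aromatic nitrogen. Set against the bromo compound, the reading is a 1.2-fold lower number from compound 1 to compound 3 (0.07 log units; within the scatter) for 3-methylphenyl in place of 2-bromophenyl at that same place, so all three substituted phenyl groups shown here cannot be told apart on these numbers. No measurement available here accounts for how close these values lie.

From the compounds shown here alone, what remains open is whether this position would respond the same way to a group of another kind, such as an amine, a carboxylic acid or a longer chain on the phenyl ring. The three compounds show only that a methyl or bromo group on this ring, in the places tested, leaves the reading within the usual scatter, and they cannot say how far that holds for anything else placed there.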